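The source may report more compounds than this note shows. Statements on the series, on what has been measured and on what is new or still open speak of the compounds shown alone.

Measured so far:
- compound 1 `CNc1nc(-c2ccccc2)nc2c1nnn2Cc1ccccc1`: 353 nM in an assay on Cerebral cortex for displacement of a labelled ligand from adenosine receptor A1 (Bos taurus); on this read-out lower numbers stand for stronger inhibition and higher numbers for weaker inhibition
- compound 2 `CCNc1nc(-c2ccccc2)nc2c1nnn2Cc1ccccc1`: 91 nM in this assay
- compound 3 `CCNc1nc(-c2ccccc2)nc2c1nnn2Cc1ccccc1Cl`: 463 nM in this assay

Compound 2 holds the lowest number of the three, with a 3.9-fold lower number from compound 1 to compound 2 (0.59 log units; beyond the scatter) and, in the other direction, a 5.1-fold higher number from compound 2 to compound 3 (0.71 log units; beyond the scatter). Compound 4 `CCCCNc1nc(-c2ccccc2)nc2c1nnn2Cc1ccccc1` carries ethyl in place of hydrogen on a saturated chain carbon, two bonds along the chain from a nitrogen on an aromatic ring. Within the data shown here, only one measured step bears on it: the chain lengthening a 3.9-fold lower number from compound 1 to compound 2 (0.59 log units; beyond the scatter), which lowered the number by a modest amount; the chloro step from compound 2 to compound 3 touches a different part and gives no guidance. A single step is a thin basis, and a second lengthening need not repeat the first, so for compound 4 in this assay a small lowering or none beyond the scatter is expected, a 1.7-fold lower number from compound 2 to compound 4 (0.22 log units; within the scatter). Compound 4 is estimated at 55 nM, within 18 nM to 170 nM.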

Compound 4, inhibition constant: 11 nM
Compound 4: the middle estimate sits 5.0-fold (0.70 log units) above what was measured, outside the stated range (below it).
By their numbers in this assay, from the lowest: compound 4; then compound 2; then compounds 1 and 3 (each within the scatter of the next).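

The lowering of the number in this assay does not stop at ethyl: going from ethylamino to butylamino at this position lowers it again (an 8.3-fold lower number from compound 2 to compound 4 (0.92 log units; beyond the scatter)). Across the whole chain series, the change is large (a 32-fold lower number from compound 1 to compound 4 (1.51 log units; beyond the scatter)), and compounds 1, 2 and 4 all run in one direction. Nothing available explains why the butyl chain gives this result.

Going by these compounds, whether a longer chain such as hexyl lowers the number further, or where the trend turns, remains open. So does the effect of a branched chain, or of an amine or carboxylic acid carried on the chain.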